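A few compounds are considered here, and "the series" means these few. Any claim that something is new, unique, unknown or untested is made for them only; others in the source may bear on it.

Compound 1 `COc1ccc(C(=O)CSc2nnc(-c3cc(OC)c(OC)c(OC)c3)n2N)cc1` gives in a functional assay on HepG2 cells (Homo sapiens) for antiproliferative activity, read by MTT assay, with a stated time of 48 h (a higher number here means a weaker inhibitor, a lower number a stronger inhibitor), the value > 100000 nM, which is a limit of the assay rather than a measured number.
Compound 2 `COc1cc(-c2nnc(SCC(=O)Nc3ccccc3)n2N)cc(OC)c1OC` gives in this assay the value 49900 nM.

Among the measured compounds shown here, of these two results, compound 2 holds the only actual number; the other result sits at a limit of the assay (the limit of > 100000 nM in this assay, at which 1 of the 2 values shown sits). For the measured compounds named here, the one measured step, an at least 2.0-fold lower number from compound 1 to compound 2 (0.30 log units; that floor lies within the scatter), came from putting anilino in place of 4-methoxyphenyl on a carbonyl carbon, and its size rests on a limit.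

Compound 3 `COc1cc(-c2nnc(SCC(=O)NCc3ccc(C)cc3)n2N)cc(OC)c1OC` takes the next step from compound 2: 4-methylbenzyl in place of phenyl on an amide-type nitrogen. Going by the values given here, no measured step touches the amide nitrogen, so the only measured step bears on it just as a sign that the whole series so far lies in the weak range. With nothing pointing in either direction, no change beyond the scatter is expected in this assay.

Compound 3 is therefore estimated to give 45000 nM, with a range from 12000 nM to 150000 nM. The expected step is a 1.1-fold lower number from compound 2 to compound 3 (0.04 log units; within the scatter), and the result could also come back as a limit.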

Compound 3, half-maximal inhibitory concentration: > 100000 nM
Compound 3 gave a limit, no number; the forecaster's own chance of this, stated with the estimate: 30%; at least 2.2-fold (0.34 log units) between middle value and limit.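

Among the compounds shown here, this is the first measured step at the amide nitrogen: 4-methylbenzyl in place of phenyl gives an at least 2.0-fold higher number from compound 2 to compound 3 (0.30 log units; that floor lies within the scatter), so in this assay the larger group brings no gain, while the printed floor of the step does not by itself separate the two compounds beyond the scatter. Compound 3 gives a limit of the assay and not a number, so the step between compound 1 and compound 3 cannot be read. With this result, most of the small series now sits at one value that is not an actual number: the limit of > 100000 nM in this assay, at which 2 of the 3 values shown sit.

The compounds shown leave open whether any group on this nitrogen can give a number clearly lower than that of compound 2, 49900 nM. Plain benzyl or 4-methylphenyl on the same nitrogen would help to separate the contribution of the added carbon in the chain from that of the methyl on the ring, and an amine or a carboxylic acid at the end of a longer chain would test a quite different kind of group there.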